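This account rests on a few compounds, and the source may have more. Where it says the series, first, only, none or still open, it means among the compounds named here.

In a functional assay on aorta (Rattus norvegicus, strain Sprague-Dawley) (a higher number here means that more compound is needed for the effect, a lower number that less compound is needed), compound 1 `Cc1nn(-c2ccccc2)c2nc(O)c(-c3nc(N)cc(N)n3)cc12` has the entry "not determined" (no result reported), so this step starts without a number. Compound 4 `Cc1nn(-c2ccccc2)c2nc(OCc3cccc(F)c3)c(-c3nc(N)cc(N)n3)cc12` differs from it as follows: 3-fluorobenzyl in place of hydrogen on an oxygen on an aromatic ring. In words, 3-fluorobenzyl takes the place of hydrogen on an oxygen on an aromatic ring.

Going by the values given here, no measured step covers this change. The nearest evidence comes from two relatives that carry a fluorinated benzyl group on that oxygen but differ from compound 4 elsewhere. Compound 2 `Cc1nn(-c2ccccc2)c2nc(OCc3ccccc3F)c(-c3nc(N)c(N)c(N)n3)cc12` gives 960 nM. Compound 3 `Cc1nn(-c2ccccc2)c2nc(OCc3ccccc3F)c(-c3nc(N)c(N4CCOC4=O)c(N)n3)cc12` gives > 100000 nM, which is a limit of the assay and not a number. Among the compounds with values here, the only measured step is large: an at least 100-fold higher number from compound 2 to compound 3 (2.01 log units; beyond the scatter). It replaces amino with 2-oxo-1,3-oxazolidin-3-yl on an aromatic carbon, a change not made in compound 4, so it bears on this step only weakly.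

With no starting number, no step size or direction can be expected from compound 1. The expectation therefore rests on compound 2 at 960 nM, and a somewhat higher number is expected for compound 4. The estimated value for compound 4 is 3000 nM, with an expected range from 400 nM to 25000 nM.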

Compound 4, half-maximal effective concentration: 360 nM
For compound 4 the middle estimate is 8.3-fold (0.92 log units) above the measured one; measured number below the stated range.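

In this assay compound 1 has the entry "not determined" (no result reported), so no step can be read from compound 1 to compound 4. The compounds shown leave open how far hydroxy to (3-fluorobenzyl)oxy alone moves the concentration needed for the effect.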